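The source may report more compounds than this note shows. Statements on the series, on what has been measured and on what is new or still open speak of the compounds shown alone.

In a functional assay on SK-BR-3 cells (Homo sapiens) for antiproliferative activity (on this read-out higher numbers stand for weaker inhibition and lower numbers for stronger inhibition), compound 1 `CC(C)=CCc1cc(C(=O)Nc2cc3ccc(OCCCNCC(C)C)c(C)c3oc2=O)ccc1O` gives 1030 nM and compound 2 `CC(C)=CCc1cc(C(=O)Nc2cc3ccc(OCCCN(C)C(C)(C)C)c(C)c3oc2=O)ccc1O` gives 880 nM. These two stand together, with a 1.2-fold lower number from compound 1 to compound 2 (0.07 log units; within the scatter). Compound 3 `CC(C)=CCc1cc(C(=O)Nc2cc3ccc(OCCCNCC(=O)O)c(C)c3oc2=O)ccc1O` gives 7570 nM, the highest number of the three and so the weakest inhibition in this small set.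

Compound 4 `CC(C)=CCc1cc(C(=O)Nc2cc3ccc(OCCCNCc4ccccc4)c(C)c3oc2=O)ccc1O` differs from compound 3 as follows: phenyl in place of carboxy on a saturated chain carbon bound to an amine nitrogen. That is phenyl in place of carboxy on a saturated chain carbon bound to an amine nitrogen.

Among the measured compounds shown here, two measured steps bear on this change, as both bring in the carboxy: a 7.3-fold higher number from compound 1 to compound 3 (0.87 log units; beyond the scatter) and an 8.6-fold higher number from compound 2 to compound 3 (0.93 log units; beyond the scatter). Compound 4 loses the carboxy, so a modest step to a lower number is expected in this assay, back towards compound 1 at 1030 nM and compound 2 at 880 nM. For the measured compounds named here, no compound with a phenyl at this place has been measured, so the range stays wide.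

The estimated step is an 8.0-fold lower number from compound 3 to compound 4 (0.90 log units; beyond the scatter). For compound 4 the expected value is 950 nM, within an estimated range of 350 nM to 2600 nM.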

Compound 4, half-maximal inhibitory concentration: 470 nM
Beside the measured number, compound 4's estimate is 2.0-fold (0.31 log units) above it, within the range that was stated.
By their numbers in this assay, from the lowest: compounds 4, 2 and 1 (each within the scatter of the next, the first and the last beyond it); then compound 3.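

In this assay, among the compounds shown here, phenyl is the first ring-bearing group at this place, on a saturated chain carbon bound to an amine nitrogen, and its exchange for carboxy gives a 16-fold lower number from compound 3 to compound 4 (1.21 log units; beyond the scatter). Against the alkyl-bearing amines the picture splits: a 2.2-fold lower number from compound 1 to compound 4 (0.34 log units; beyond the scatter), a modest step, while a 1.9-fold lower number from compound 2 to compound 4 (0.27 log units; within the scatter), which does not separate the two. A six-membered aromatic ring of carbon only is therefore accepted here, and the loss seen with carboxy does not extend to this replacement of isopropyl.

As far as these compounds go, whether a phenethyl group in place of the benzyl, a pyridine ring in place of the phenyl, or a methoxy group on the phenyl would hold this level stays open. No measurement on hand explains the size of these steps.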